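A Hydroxyphenyl Swap in a Lactone Cytotoxicity Series

A few compounds are considered here, and "the series" means these few. Any claim that something is new, unique, unknown or untested is made for them only; others in the source may bear on it.

Compound 1, `O=C1OC[C@H](Cc2ccccc2)[C@H]1Cc1ccccc1F`, carries a 2-fluorophenyl group on one arm of its core. In a functional assay on HL-60 cells (Homo sapiens) for cytotoxicity, read by WST assay, with a stated time of 48 h (on this read-out higher numbers stand for an effect only at larger amounts of compound and lower numbers for an effect already at smaller amounts), compound 1 gives 72000 nM. Compound 2, `O=C1OC[C@H](Cc2ccccc2)[C@H]1Cc1cccc(O)c1`, differs from compound 1 by 3-hydroxyphenyl in place of 2-fluorophenyl on a saturated chain carbon bound to a saturated ring carbon. In this assay compound 2 reaches only a limit of the measurement, > 100000 nM. That value is not a number but (the limit of > 100000 nM in this assay, at which 1 of the 3 values shown sits). The step is therefore known only as a floor: an at least 1.3-fold higher number from compound 1 to compound 2 (0.14 log units; that floor lies within the scatter).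

Compound 3, `O=C1OC[C@H](Cc2ccccc2F)[C@H]1Cc1ccc(Cl)c(Cl)c1`, has a different core from compound 1, and how the two cores differ is not broken down here. In this assay compound 3 gives 28000 nM, a lower number than compound 1 shows and the lowest of the two numbers available.

Compound 4, `O=C1OC[C@H](Cc2cccc(O)c2)[C@H]1Cc1ccc(Cl)c(Cl)c1`, has not yet been measured. It differs from compound 3 by 3-hydroxyphenyl in place of 2-fluorophenyl on a saturated chain carbon bound to a saturated ring carbon, the same change that separates compound 1 from compound 2, made at the same place. Since the earlier change did not lower the number, compound 4 is expected to move from compound 3 by a 2.1-fold higher number from compound 3 to compound 4 (0.33 log units; beyond the scatter). This expectation rests on the earlier step of an at least 1.3-fold higher number from compound 1 to compound 2 (0.14 log units; that floor lies within the scatter), and it carries real uncertainty, since that step is only a floor set by a limit. Compound 4 is therefore estimated at 60000 nM in this assay, with a likely range from 25000 nM to 150000 nM.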

Compound 4, half-maximal effective concentration: 48000 nM
Compound 4: middle estimate off by 1.3-fold (0.10 log units), on the high side, within the range that was stated.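

Replacing 2-fluorophenyl with 3-hydroxyphenyl on the core of compound 3 gives, in this assay, a 1.7-fold higher number from compound 3 to compound 4 (0.23 log units; within the scatter). Set beside the same change on the core of compound 1, the comparison reaches only this far: the same change on two cores in this assay, an at least 1.3-fold higher number (0.14 log units; that floor lies within the scatter) from compound 1 to compound 2 and a 1.7-fold higher number (0.23 log units; within the scatter) from compound 3 to compound 4; the limit leaves it open whether they differ. Going by these compounds, neither step is printed as beyond the usual scatter, but the step on the core of compound 1 is only a floor and its true size stays unknown, so the pair does not show that the change has the same size on both cores, nor that it truly moves the number on the core of compound 3.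

The compounds shown leave open whether a different group on that saturated chain carbon, such as an amine or a carboxylic acid, would give a step clearly beyond the scatter in this assay. They also leave open how the change behaves on a third core and whether a longer chain carrying the same aromatic ring would alter the picture, and two cores are too few to support a rule for the whole series.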